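A few compounds are considered here, and "the series" means these few. Any claim that something is new, unique, unknown or untested is made for them only; others in the source may bear on it.

Working notes on the series. Three compounds have numbers in a functional assay on RAW264.7 cells (Mus musculus) for inhibition; a higher number here means a weaker inhibitor, a lower number a stronger inhibitor. Compound 1 `CC1=C(c2cc[n+]([O-])cc2)S(=O)(=O)N(Cc2ccc(C(=O)N3CCCCC3)cc2)C1=O` gives 79400 nM in this assay. Compound 2 `O=C(c1ccc(CN2Cc3ccccc3C2=O)cc1)N1CCCCC1` gives 21900 nM in this assay. Compound 3 `O=C(c1ccc(Cn2c(=O)c3ccccc3[s+]2[O-])cc1)N1CCCCC1` gives 49000 nM in this assay, which places it second highest of the three; its nearest neighbour is compound 1, whose number differs by an amount within the scatter, so no order between compound 1 and compound 3 is claimed, while compound 2 sits further off, beyond the scatter, with the lower number of the two.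

The next step leaves the core of compound 3 unchanged and alters the amide end: ((furan-2-yl)methyl)amino in place of piperidin-1-yl on a carbonyl carbon. This gives compound 4 `O=C(NCc1ccco1)c1ccc(Cn2c(=O)c3ccccc3[s+]2[O-])cc1`, not yet measured in this assay. Going by the values given here, no measured pair in the set shows this exchange, so there is no step to lean on. The expectation is therefore a step of small size, likely no further than the scatter, with no clear direction, and compound 4 is estimated to land near the number of compound 3. Compound 4 is expected at 50000 nM in this assay, with a range from 15000 nM to 150000 nM, which means an expected step of a 1.0-fold higher number from compound 3 to compound 4 (0.01 log units; within the scatter).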

Compound 4, half-maximal inhibitory concentration: 23300 nM
For compound 4 the middle estimate is 2.1-fold (0.33 log units) above the measured one; low and high end bracket the measured number.
By their numbers in this assay, from the lowest: compounds 2 and 4 (each within the scatter of the next); then compounds 3 and 1 (each within the scatter of the next).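

In this assay, ((furan-2-yl)methyl)amino in place of piperidin-1-yl on a carbonyl carbon gives a 2.1-fold lower number from compound 3 to compound 4 (0.32 log units; beyond the scatter), a modest step. Going by these compounds alone, compounds 1, 2 and 3 all carry piperidin-1-yl at this place and differ elsewhere, so they said nothing about the amide end; this step is the first reading of it and shows that the number responds to a change here, with the shared core held constant, and that the piperidine ring can be given up without a weaker number. Nothing available bears on why the number moves, and the exchange alters several things at once, the ring, the heavy-atom count and the amide hydrogen, so the step cannot be assigned to any one of them.

Open, going by these compounds, is whether the step follows the furan ring, the methylene link or the amide hydrogen, which a benzylamino, a methylamino or a morpholin-4-yl group at the same place would help separate. Also open, on these data alone, is whether the same exchange moves the number in the same direction on the cores of compound 1 and compound 2.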